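Pyrrolidine in Place of a Terminal Ethyl on a Chain

The compounds below may be only part of what the source reports. "The series", "measured", "known", "first", "only" and "open" are said of these compounds alone.

Measured compounds:
compound 1, `CCCCNc1nc(N)nc(C)c1CCCN1C(=O)c2ccccc2C1=O`: 453 nM
compound 2, `CCCCNc1nc(N)nc(C)c1CCCn1c(C)nc2ccccc21`: 366 nM
compound 3, `CCCCCc1c(C)nc(N)nc1NCCCC`: 1220 nM

The three measured compounds share one core and differ only in what hangs from the saturated chain on that core. Compound 1 and compound 2 each carry a ring system at the end of the chain, and in an assay on HEK293 cells for agonist activity at Toll-like receptor 8 (Homo sapiens), read by spectrophotometry (on this read-out lower numbers stand for an effect already at smaller amounts and higher numbers for an effect only at larger amounts of compound), compound 1 gives 453 nM while compound 2 gives 366 nM. Compound 3 carries a plain chain with no ring and gives 1220 nM, the highest of the three numbers; its gaps to compound 1 and to compound 2 both lie beyond the scatter.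

Compound 4, `CCCCNc1nc(N)nc(C)c1CCCN1CCCC1`, is not yet measured. It differs from compound 3 in one place: pyrrolidin-1-yl in place of ethyl on a saturated chain carbon, three bonds along the chain from an aromatic carbon. With this change the chain again ends in a ring, as in compound 1 and compound 2, though a smaller, non-aromatic one. By analogy the number is expected to move downward, and the step of a 2.4-fold lower number from compound 3 to compound 4 (0.39 log units; beyond the scatter) is estimated to reach beyond the scatter. Compound 4 is expected to give 500 nM, with a range from 200 nM to 1500 nM.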

Compound 4, half-maximal effective concentration: 110 nM
Compound 4: middle estimate off by 4.5-fold (0.66 log units), on the high side; the measured number lies below the stated range.
By their numbers in this assay, from the lowest: compound 4; then compounds 2 and 1 (each within the scatter of the next); then compound 3.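

In this assay the saturated chain carbon three bonds along the chain from an aromatic carbon proves highly sensitive to a single change, since pyrrolidin-1-yl in place of ethyl gives an 11-fold lower number from compound 3 to compound 4 (1.04 log units; beyond the scatter) and so a large step beyond the scatter. Among the ring-bearing chains, compound 4 gives 110 nM with the smallest ring and the lowest number of the set, so a larger ring system is not needed for a low number here. No measurement at hand accounts for the size of this step.

The compounds shown leave open whether the ring or its nitrogen carries the step, which an open-chain diethylamino group or a cyclopentyl ring would test. Also open, as far as these compounds go, is how a piperidine or morpholine ring, or a shorter or longer chain bearing pyrrolidin-1-yl, would read.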